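Adding 3-hydroxybut-1-yn-1-yl to the core of compound 1

The compounds below may be only part of what the source reports. "The series", "measured", "known", "first", "only" and "open" are said of these compounds alone.

Compound 1 `Nc1ccc(S(=O)(=O)c2ccc(-c3ccc(C(O)(C(F)(F)F)C(F)(F)F)cn3)cc2)cn1` is the unsubstituted member of this set. In an ADME assay (liver) for metabolic stability, with Liver microsome (Rattus norvegicus) as the target, using microsomes and NADPH, with a stated time of 30 min, at 37 degrees C, tested at 1 uM (a higher number here means faster removal of the compound, a lower number slower removal), compound 1 gives < 14 mL.min-1.g-1, which is a limit of the assay and not a number, so its standing on the numbers shown is fixed only as the limit of < 14 mL.min-1.g-1 in this assay, at which 1 of the 3 values shown sits. Compound 2 `Nc1ccc(S(=O)(=O)c2ccc(-c3ncc(C(O)(C(F)(F)F)C(F)(F)F)cc3Cl)cc2)cn1` carries chloro in place of hydrogen on an aromatic carbon and gives 18 mL.min-1.g-1 in this assay. Compound 3 `N#Cc1cc(C(O)(C(F)(F)F)C(F)(F)F)cnc1-c1ccc(S(=O)(=O)c2ccc(N)nc2)cc1` carries cyano in place of hydrogen on an aromatic carbon and gives 27 mL.min-1.g-1 in this assay. The two steps from the parent are an at least 1.2-fold higher number from compound 1 to compound 2 (0.10 log units; that floor lies within the scatter) and an at least 1.9-fold higher number from compound 1 to compound 3 (0.28 log units; that floor lies within the scatter); between the substituted pair the step is a 1.5-fold higher number from compound 2 to compound 3 (0.18 log units; within the scatter).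

Compound 4 `C[C@H](O)C#Cc1cc(C(O)(C(F)(F)F)C(F)(F)F)cnc1-c1ccc(S(=O)(=O)c2ccc(N)nc2)cc1` differs from compound 1 by 3-hydroxybut-1-yn-1-yl in place of hydrogen on an aromatic carbon. For the measured compounds named here, the steps that bear on it are the two replacements of a hydrogen on an aromatic carbon of the core, both of which gave a higher number from the limit, though each floor lies within the scatter. On that basis compound 4 is expected to leave the limit and show a number somewhat above it, estimated as 30 mL.min-1.g-1 with a range of 12 mL.min-1.g-1 to 75 mL.min-1.g-1, meaning an expected step of an at least 2.1-fold higher number from compound 1 to compound 4 (0.33 log units; beyond the scatter).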

Compound 4, intrinsic clearance in microsomes: 29 mL.min-1.g-1
Compound 4: the middle estimate sits 1.0-fold (0.01 log units) above what was measured, and the stated range covers the measured number.
By their numbers in this assay, from the lowest: compounds 2, 3 and 4 (each within the scatter of the next). At a limit, below all of these: compound 1.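

In this assay, 3-hydroxybut-1-yn-1-yl in place of hydrogen on this aromatic carbon gives an at least 2.0-fold higher number from compound 1 to compound 4 (0.31 log units; beyond the scatter), and this is the only step from compound 1 shown whose floor lies beyond the scatter, as the chloro and cyano floors lie within it. The new group does not separate from either smaller replacement at the same position, with a 1.1-fold higher number from compound 3 to compound 4 (0.03 log units; within the scatter) and a 1.6-fold higher number from compound 2 to compound 4 (0.21 log units; within the scatter), so a chain with a triple bond, a hydroxyl and a defined stereocentre reads the same here as cyano or chloro. Compound 1 remains the only compound at a limit, which is not a number, so every step from it is a floor: the limit of < 14 mL.min-1.g-1 in this assay, at which 1 of the 4 values shown sits.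

Going by these compounds, the true size of the steps from compound 1 stays open, as does the question of how far any substituent at this position, whatever its kind, sets the number. On these data alone, the share of the hydroxyl, the triple bond and the stereocentre also stays open, and the opposite stereoisomer, the same chain without its hydroxyl, or a chain ending in an amine or a carboxylic acid would bear on it.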